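This account rests on a few compounds, and the source may have more. Where it says the series, first, only, none or still open, it means among the compounds named here.

Working notes on the series. In a functional assay on B16-F10 cells (Mus musculus) for inhibition, read by colorimetric assay and MTT assay, with a stated time of 72 h (on this read-out higher numbers stand for weaker inhibition and lower numbers for stronger inhibition), compound 1 (`C=CCCOc1ncc(-c2ccccc2OC)n1C`) is recorded as "not determined" (no result reported), and compound 2 (`C=CCCCCOc1ncc(-c2ccccc2OC)n1C`) is also recorded as "not determined" (no result reported). Compound 2 therefore has no place on the numerical scale, and the same holds for compound 1. For the measured compounds named here, the only number so far belongs to compound 3 (`C=CCCCCOc1ncc(-c2cc(Cl)ccc2OC)n1C`), which gives 29000 nM.

The next compound to read is compound 4 (`C=CCCCCOc1ncc(-c2ccc(Cl)cc2OC)n1C`). The structural step is chloro in place of hydrogen on an aromatic carbon, meta to a methoxy group and para to a large group.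

Going by the values given here, no measured step between two compounds is available, so the effect of this change in this assay cannot be sized from the data. A modest step towards stronger inhibition relative to compound 2 is expected, but without a number for compound 2 this remains a qualitative expectation. Among the compounds with values here, the numerical anchor is compound 3 at 29000 nM, the only chloro compound measured so far, and a single value supports only a wide range. A report of a limit instead of a number also remains possible.

For compound 4 the estimated value is 25000 nM, with an expected range of 10000 nM to 60000 nM.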

Compound 4, half-maximal inhibitory concentration: 43000 nM
The estimate for compound 4 lay 1.7-fold (0.24 log units) below the measured number; low and high end bracket the measured number.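

No new step can be read for compound 4: compound 2, which differs from it in one place, has no number in this assay. No evidence bearing on this result is at hand. The compounds shown leave open how chloro in place of hydrogen changes inhibition in this series.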